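The source may report more compounds than this note shows. Statements on the series, on what has been measured and on what is new or still open speak of the compounds shown alone.

Measured so far in an assay on CHO cells for displacement of a labelled ligand from adenosine receptor A3 (Homo sapiens), read by scintillation counting, with a stated time of 120 min, tested at 10 uM; on this read-out higher numbers stand for more inhibition at the one concentration tested (going by the name of the read-out) and lower numbers for less inhibition:

- compound 1 `Nc1scc(CN2CCN(c3ccc(Cl)cc3Cl)CC2)c1C(=O)c1ccc(Cl)cc1`: 0%
- compound 2 `Nc1scc(CN2CCN(c3ccc(F)cc3Cl)CC2)c1C(=O)c1ccc(Cl)cc1`: 0%

Compound 2 stands level with compound 1; the step from the one to the other, no change at the digits printed from compound 1 to compound 2 (within the scatter), is within the scatter, so neither shows anything at the single concentration tested and no order between them can be read.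

Compound 3 `Nc1scc(CN2CCN(c3ccc(Cl)cc3F)CC2)c1C(=O)c1ccc(Cl)cc1` has not been measured. It differs from compound 2 only in the arrangement of the halogen-bearing ring on the amine nitrogen in a ring:

4-chloro-2-fluorophenyl in place of 2-chloro-4-fluorophenyl on an amine nitrogen in a ring

Among the compounds with values here, the only measured step that bears on a change at this ring is the one from compound 1 to compound 2, which replaced chloro with fluoro on an aromatic carbon and left the read-out unchanged. Within the data shown here, the change to compound 3 keeps the same atoms and only exchanges the two halogen positions, and there is no measured step that separates these positions. Among the measured compounds shown here, with both measured compounds showing nothing and the one relevant step flat, the step expected for compound 3 in this assay is no change at the digits printed from compound 2 to compound 3 (within the scatter), no change beyond the scatter.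

Compound 3 is therefore estimated at 0%, within -8% to 10%.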

Compound 3, a percentage reported as inhibition, at one concentration (the size of the read-out at that concentration, not a potency): 1%
For compound 3 the middle estimate is 1 percentage points below the measured one, and the stated range covers the measured number.
By their numbers in this assay, from the lowest: compounds 1, 2 and 3 (each within the scatter of the next).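

Working notes on the halogen-bearing ring: in this assay, 4-chloro-2-fluorophenyl in place of 2-chloro-4-fluorophenyl on the amine nitrogen gives a number 1 percentage points higher from compound 2 to compound 3 (within the scatter), so this exchange of the two halogens, with the same atoms joined differently, is the first measured change of arrangement at this place and it does not move the read-out beyond the scatter. Fluoro in place of chloro on an aromatic carbon, now made with the 4-chloro kept rather than the 2-chloro, gives a number 1 percentage points higher from compound 1 to compound 3 (within the scatter), so this replacement is flat at both ring places covered by compound 2 and compound 3. No measurement available here gives a reason for these flat steps.

From the compounds shown here alone, all three compounds sit close to nothing at the one concentration tested, so it stays open whether the halogen arrangement would matter in a compound with a clear read-out. Also open, going by these compounds, is whether a methoxy group or an amine on this phenyl ring, or a carboxylic acid elsewhere on the shared core, would give a number beyond the scatter.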